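The source may hold more compounds than are shown below. What is called first, only, known or untested is meant among the compounds shown, and "the series" means these compounds.

Compound 1 `O=S(=O)(/C=C/c1ccccc1)Nc1ccccc1` gives > 10000 nM in an assay on U2OS cells for activation of nuclear factor erythroid 2-related factor 2 (Homo sapiens), read by chemiluminescence, with a stated time of 6 h (on this read-out lower numbers stand for an effect already at smaller amounts and higher numbers for an effect only at larger amounts of compound), which is a limit of the assay rather than a number.
Compound 2 `O=S(=O)(/C=C/c1ccccc1Cl)Nc1ccccc1` gives > 10000 nM in this assay, again a limit.
Compound 3 `COc1ccc(OS(=O)(=O)/C=C/c2ccccc2)cc1` gives 1480 nM in this assay.

Compound 1 and compound 2 are the pair that carries the measured version of the change of interest: from compound 1 to compound 2 the difference is chloro in place of hydrogen on an aromatic carbon, and the step is a step that the two limits leave unreadable from compound 1 to compound 2. Its size cannot be read since both values sit at the limit of > 10000 nM in this assay, at which 2 of the 3 values shown sit. The difference between the core of compound 1 and the core of compound 3 is not broken down here. Compound 4 `COc1ccc(OS(=O)(=O)/C=C/c2ccccc2Cl)cc1` has not yet been measured in this assay. For the measured compounds named here, it differs from compound 3 by chloro in place of hydrogen on an aromatic carbon, which is the same change, at the same place, as the one from compound 1 to compound 2. With the measured instance unreadable, the expectation for compound 4 rests on compound 3 alone, which gives 1480 nM in this assay. Compound 4 is expected to give 1500 nM in this assay. That estimate means a step of a 1.0-fold higher number from compound 3 to compound 4 (0.01 log units; within the scatter). The expected range for compound 4 runs from 500 nM to 5000 nM.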

Compound 4, half-maximal effective concentration: 237 nM
Beside the measured number, compound 4's estimate is 6.3-fold (0.80 log units) above it; the whole stated range lies above it.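

In this assay, chloro in place of hydrogen on the core of compound 3 brings a 6.2-fold lower number from compound 3 to compound 4 (0.80 log units; beyond the scatter), so on this core the change has a readable size. For the compounds shown here, this does not show that the change carries from one core to another, since the only other instance of it cannot be read, because compound 1 and compound 2 both stand at a limit of the assay rather than at a number: the limit of > 10000 nM in this assay, at which 2 of the 4 values shown sit. The two cores therefore cannot be compared for this change, and the series offers one readable step, which gives neither agreement nor disagreement between them.

The compounds shown leave open whether chloro is needed for this step or whether fluoro, bromo, methyl or methoxy in the same place on the aromatic ring would give a similar one. They also leave open how the core of compound 3 would respond to an amine or a carboxylic acid on that ring.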